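The source may hold more compounds than are shown below. What is called first, only, known or untested is meant among the compounds shown, and "the series" means these compounds.

Compound 1 `Cc1cc(=O)c2c(O)cc(OCc3ccccc3)c([C@H]3CCN(C)C[C@H]3O)c2o1` gives 1%
Compound 2 `Cc1cc(=O)c2c(O)cc(OCc3ccc(Br)cc3)c([C@H]3CCN(C)C[C@H]3O)c2o1` gives 14%
Compound 3 `Cc1cc(=O)c2c(O)cc(OC/C=C/c3ccccc3)c([C@H]3CCN(C)C[C@H]3O)c2o1` gives 7%

All three values come from a functional assay on MCF7 cells (Homo sapiens) for inhibition, read by MTT assay, with a stated time of 48 h, tested at 10 uM (a higher number here means more inhibition of growth at the concentration tested, a lower number less inhibition of growth), and all are small. Compound 3 has no clear rank among them, as its steps to both neighbours stay inside the scatter: a number 6 percentage points higher from compound 1 to compound 3 (within the scatter) and a number 7 percentage points lower from compound 2 to compound 3 (within the scatter) are the two in question.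

Compound 4 `Cc1cc(=O)c2c(O)cc(OCc3ccco3)c([C@H]3CCN(C)C[C@H]3O)c2o1` has not yet been measured. It carries furan-2-yl in place of 2-phenylethenyl on a saturated chain carbon bound to an oxygen on an aromatic ring, and the count of that difference reads furan-2-yl in place of 2-phenylethenyl on a saturated chain carbon bound to an oxygen on an aromatic ring as the change.

The two steps into compound 3 bear most directly, since they alter the same place, and neither moves the number beyond the scatter. Going by the values given here, the only step that does is a number 13 percentage points higher from compound 1 to compound 2 (beyond the scatter), a modest one, for bromo in place of hydrogen on an aromatic carbon. Among the compounds with values here, no measured compound yet carries a furan-2-yl group, so the data give no direct reading of this group. In this assay no step beyond the scatter is therefore expected, and no direction can be claimed with confidence. The expected change is a number 2 percentage points lower from compound 3 to compound 4 (within the scatter) and no more. The estimate for compound 4 is 5%, with an expected range from 0% to 15%.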

Compound 4, percent growth inhibition at one concentration: 6%
Estimate against measurement, compound 4: 1 percentage points below, and the stated range covers the measured number.
By their numbers in this assay, from the lowest: compounds 1, 4, 3 and 2 (each within the scatter of the next, the first and the last beyond it).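

In this assay the furan-2-yl group brings a five-membered aromatic ring with a hetero atom to this place, on a saturated chain carbon bound to an oxygen on an aromatic ring, and the number stays level with all three earlier groups (a number 1 percentage points lower from compound 3 to compound 4 (within the scatter); a number 5 percentage points higher from compound 1 to compound 4 (within the scatter); a number 8 percentage points lower from compound 2 to compound 4 (within the scatter)). Replacing the 2-phenylethenyl of 8 heavy atoms with a furan-2-yl of 5 heavy atoms, which adds a hydrogen-bond acceptor and removes the double bond outside aromatic rings, therefore leaves no reading beyond the scatter at this place. Compound 4 also falls within the scatter of both compound 1 and compound 2, so the one step beyond it, a number 13 percentage points higher from compound 1 to compound 2 (beyond the scatter), remains the only separation among these compounds, and every number stays small.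

As far as these compounds go, whether an amine, a carboxylic acid or a longer chain in place of these aromatic groups would lift growth inhibition beyond the scatter remains open. Nothing given on these compounds accounts for the low numbers at this place.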